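This account rests on a few compounds, and the source may have more. Where it says the series, first, only, none or still open, it means among the compounds named here.

Measured compounds:
- Compound 1, `COc1ccccc1/C=C/C(=O)/C=C/c1ccc(OCc2cn(CCCCCOc3cc(=O)oc4ccccc34)nn2)c(OC)c1`: 33%
- Compound 2, `COc1ccc(/C=C/C(=O)/C=C/c2ccc(OCc3cn(CCOc4cc(=O)oc5ccccc45)nn3)c(OC)c2)cc1OC`: 82%

Both compounds were tested in a functional assay on HCT-116 cells (Homo sapiens) for inhibition, read by sulforhodamine B assay, with a stated time of 48 h, tested at 50 uM; on this read-out higher numbers stand for more inhibition of growth at the one concentration tested and lower numbers for less inhibition of growth. Among the measured compounds shown here, compound 1 gives the lowest of the two numbers; the only other compound, compound 2, gives a value that is higher, and the gap between the two lies beyond the usual scatter of repeated measurements. Compound 2 differs from compound 1 in more than one place, so its higher reading is simply what the numbers show and is not traced to any single change.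

Compound 3, `COc1cc(/C=C/C(=O)/C=C/c2ccco2)ccc1OCc1cn(CCCCCOc2cc(=O)oc3ccccc23)nn1`, has not been measured yet. It differs from compound 1 in one place: furan-2-yl in place of 2-methoxyphenyl on a double-bonded chain carbon bound to a double-bonded chain carbon. The rest of the molecule, including the shared core, is unchanged.

For the measured compounds named here, no single-point step between measured compounds is available to guide this change, so the expected step from compound 1 to compound 3 in this assay is small, perhaps a slight gain, and may well stay within the scatter. On that basis, compound 3 is estimated to give about 40%, with a plausible range from 15% to 70%, which amounts to an expected step of a number 7 percentage points higher from compound 1 to compound 3 (within the scatter).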

Compound 3, percent growth inhibition at one concentration: 37%
Compound 3: the middle estimate sits 3 percentage points above what was measured; low and high end bracket the measured number.
By their numbers in this assay, from the lowest: compounds 1 and 3 (each within the scatter of the next); then compound 2.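

Among the compounds shown here, putting furan-2-yl in place of 2-methoxyphenyl on a double-bonded chain carbon bound to a double-bonded chain carbon gives, in this assay, a number 4 percentage points higher from compound 1 to compound 3 (within the scatter), and this is the first comparison in the set in which only one place differs. The position therefore accepts a five-membered aromatic ring with one hetero atom in place of a six-membered aromatic ring of carbon only, and the reading cannot be told apart from that of compound 1 even though the entering group has fewer heavy atoms. Nothing available here explains why these two groups read alike, so the result stands as an observation only.

On these data alone, whether a group of a different kind at this position, such as a piperidine ring or a phenyl ring carrying a carboxylic acid, would move the reading beyond the scatter remains open. Also open, as far as these compounds go, is whether furan-2-yl and 2-methoxyphenyl would still read alike on a molecule with a longer chain, or at a concentration other than the single one used in this assay.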